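Trimming a Protected Amine to a Methyl Group

The source may report more compounds than this note shows. Statements on the series, on what has been measured and on what is new or still open speak of the compounds shown alone.

The measured compounds so far:
compound 1 `CC(C)(C)c1ccc(C(=O)N2CCC3(CC2)C(=O)N(CC(=O)N2CCCCC2CCO)CN3c2ccccc2)cc1` gives 6100 nM in an assay on HEK293 cells for displacement of a labelled ligand from NPC1-like intracellular cholesterol transporter 1 (Homo sapiens); a lower number here means a stronger inhibitor, a higher number a weaker inhibitor;
compound 2 `CC(C)(C)c1ccc(C(=O)N2CCC3(CC2)C(=O)N(CC(=O)NCCN)CN3c2ccccc2)cc1` gives 7000 nM;
compound 3 `CC(C)(C)OC(=O)NCC1CCCN(C(=O)CN2CN(c3ccccc3)C3(CCN(C(=O)c4ccc(C(C)(C)C)cc4)CC3)C2=O)C1` gives 9500 nM.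

Compound 3 has the highest of the three numbers, yet its gaps to compound 2 and compound 1 both lie within the scatter, so nothing separates the three on this evidence. Going by the values given here, the one measured step, a 1.1-fold higher number from compound 1 to compound 2 (0.06 log units; within the scatter), swapped a sizeable substituent on a carbonyl carbon for a much smaller one and moved the number not at all beyond the scatter.

Compound 4 `CCC1CCCN(C(=O)CN2CN(c3ccccc3)C3(CCN(C(=O)c4ccc(C(C)(C)C)cc4)CC3)C2=O)C1` is the unmeasured partner of compound 3. The change is methyl in place of (tert-butoxycarbonyl)amino on a saturated chain carbon bound to a saturated ring carbon. Among the compounds with values here, no measured pair tests exactly this change, and the only step available shows the shared core tolerating a large swap at the amide without consequence. Compound 3, with its extra donor and acceptors, is no better than its neighbours, so the loss of them in compound 4 is expected to matter little. The estimate for compound 4 is therefore 9000 nM, with a range from 3000 nM to 27000 nM. This estimate corresponds to a step of a 1.1-fold lower number from compound 3 to compound 4 (0.02 log units; within the scatter), which is expected to remain within the scatter.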

Compound 4, half-maximal inhibitory concentration: 3900 nM
Beside the measured number, compound 4's estimate is 2.3-fold (0.36 log units) above it, and the stated range covers the measured number.
By their numbers in this assay, from the lowest: compounds 4, 1, 2 and 3 (each within the scatter of the next, the first and the last beyond it).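

Going by these compounds alone, replacing (tert-butoxycarbonyl)amino with methyl on a saturated chain carbon bound to a saturated ring carbon gave, in this assay, a modest change (a 2.4-fold lower number from compound 3 to compound 4 (0.39 log units; beyond the scatter)), and it is the first step in this set to lie beyond the scatter, so this position does respond to what it carries. The steps from the other two compounds stay within the scatter (a 1.8-fold lower number from compound 2 to compound 4 (0.25 log units; within the scatter); a 1.6-fold lower number from compound 1 to compound 4 (0.19 log units; within the scatter)), which means compound 4 stands apart only from compound 3. Nothing available here accounts for the step from compound 3 to compound 4.

The compounds shown leave open how a free amine, a hydroxyl or a longer alkyl chain would read at this place. They also cannot say whether the step follows the size of the departing group or the carbamate itself.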